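This account rests on a few compounds, and the source may have more. Where it says the series, first, only, none or still open, it means among the compounds named here.

Measured so far:
compound 1, `CNC(=O)c1cc(C(=O)NC2CCC2)cn(Cc2ccccn2)c1=O`: >= 103 ug/mL
compound 2, `CNC(=O)c1cc(C(=O)NCCO)cn(Cc2ccccc2)c1=O`: >= 140 ug/mL

Both measured values in a physicochemical assay for solubility (a lower number here means a less soluble compound, a higher number a more soluble compound), are limits of the assay rather than numbers. Compound 1 sits at the limit of >= 103 ug/mL in this assay, at which 1 of the 2 values shown sits. Compound 2 sits at the limit of >= 140 ug/mL in this assay, at which 1 of the 2 values shown sits. Going by the values given here, compound 2 therefore stands only at a limit in this assay; how far its solubility actually lies beyond that limit is not known from these data, and no step between measured compounds is available to compare against.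

Compound 3, `CNC(=O)c1cc(C(=O)NC)c(=O)n(Cc2ccccc2)c1`, has not yet been measured. It differs from compound 2 in one place: hydrogen in place of hydroxymethyl on a saturated chain carbon bound to an amide-type nitrogen. Among the compounds with values here, with no measured step in the set to lean on, the expectation for this change is a step downward in this assay of modest size, possibly no larger than the usual scatter, and with a real chance that the assay again reports only a limit. Compound 3 is estimated at 100 ug/mL, ranging from 40 ug/mL to 220 ug/mL. The expected step from compound 2 to compound 3 is an at least 1.4-fold lower number from compound 2 to compound 3 (0.14 log units; that floor lies within the scatter).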

Compound 3, solubility: >= 118 ug/mL
Compound 3: only a limit was reported; the forecaster's own chance of this, stated with the estimate: 40%; at least 1.1-fold (0.07 log units) between middle value and limit.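

In this assay compound 3 gives >= 118 ug/mL, which is a limit and not a number. Compound 2 also stands at a limit, so the step between compound 2 and compound 3 cannot be read. Still open is how far each of the compounds shown lies beyond its limit, and whether hydrogen in place of hydroxymethyl changes the read-out at all.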